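One added chloro on a compound at the assay limit

The source may hold more compounds than are shown below. What is called first, only, known or untested is meant among the compounds shown, and "the series" means these compounds.

Measured in a functional assay on CEM-SS cells (Homo sapiens) for cytotoxicity; a lower number here means a stronger inhibitor, a higher number a weaker inhibitor:
Compound 1 `Clc1cccc(Cn2c(Cl)nc3cc(Cl)c(Cl)cc32)c1`: > 100000 nM
Compound 2 `Clc1cc2nc(Br)n(Cc3ccccc3)c2cc1Cl`: > 100000 nM

Compound 2 stands at > 100000 nM, which is a limit of the assay and not a number. Compound 1 gives > 100000 nM, which is also a limit. Together they make up the whole record so far: the limit of > 100000 nM in this assay, at which 2 of the 2 values shown sit.

The next compound, compound 3 `Clc1cccc(Cn2c(Br)nc3cc(Cl)c(Cl)cc32)c1`, departs from compound 2 in one place. It has chloro in place of hydrogen on an aromatic carbon, on a six-membered aromatic ring of carbon only, meta to a large group: chloro in place of hydrogen on an aromatic carbon.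

Among the measured compounds shown here, no measured pair shows the size of such a change here, so this forecast is cautious. The expectation rests on compound 2, with its limit of > 100000 nM, and no step beyond the scatter is expected in this assay. The estimated change is a number no higher from compound 2 to compound 3 (the limit leaves the size open). A report of only a limit again is the likeliest outcome. For compound 3 the expected value is 100000 nM, with an estimated range from 40000 nM to 200000 nM.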

Compound 3, half-maximal inhibitory concentration: > 100000 nM
Compound 3: no number, only a limit; the forecaster's own chance of this, stated with the estimate: 80%; the middle value sits exactly at the limit.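

In this assay compound 3 gives > 100000 nM, which is a limit of the assay and not a number, so its steps from compound 2 and from compound 1 cannot be read. The compounds shown leave open whether chloro in place of hydrogen, or bromo in place of chloro, on an aromatic carbon changes the strength of inhibition at all.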